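The source may hold more compounds than are shown below. What is called first, only, known or untested is meant among the compounds shown, and "the series" means these compounds.

Measured compounds:
Compound 1, `CC(=O)OCc1ccc2oc(=O)c(C(=O)Oc3cccc(Br)c3)cc2c1`: 11.8%
Compound 2, `CC(=O)OCc1ccc2oc(=O)c(C(=O)Sc3cccc(Br)c3)cc2c1`: 67.8%
Compound 3, `CC(=O)OCc1ccc2oc(=O)c(C(=O)Nc3cccc(Cl)c3)cc2c1`: 42.8%

In a functional assay on HT-1080 cells (Homo sapiens), read by transwell migration, with a stated time of 24 h, tested at 10 uM (a lower number here means a stronger effect, a higher number a weaker effect of the compound at the concentration tested), compound 1 gives the lowest of the three numbers. Compound 3 lies nearest to it, with a number 31 percentage points higher from compound 1 to compound 3 (beyond the scatter), and compound 2 lies furthest, with a number 56 percentage points higher from compound 1 to compound 2 (beyond the scatter). Between the other two, a number 25 percentage points lower from compound 2 to compound 3 (beyond the scatter). All three of these steps change the group attached to a carbonyl carbon; none of them touches the acetoxy group, which is the same in all three measured compounds.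

Compound 4, `CCCCCCC(=O)OCc1ccc2oc(=O)c(C(=O)Oc3cccc(Br)c3)cc2c1`, differs from compound 1 in exactly that untouched part: pentyl in place of hydrogen on a saturated chain carbon bound to a carbonyl carbon. Within the data shown here, no measured step bears on this place, so the three steps give no direct guide, and the expectation rests only on the fact that the part of the molecule varied in the measured steps is kept as in compound 1. The account therefore expects compound 4 to stay close to compound 1, with an expected step of a number 8.2 percentage points higher from compound 1 to compound 4 (within the scatter), small and not clearly beyond the scatter. The estimate for compound 4 is 20%, expected to fall within 5% to 45%.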

Compound 4, a percentage reported as activity, at one concentration (the size of the read-out at that concentration, not a potency): 36%
Compound 4: middle estimate off by 16 percentage points, on the low side; low and high end bracket the measured number.
By their numbers in this assay, from the lowest: compound 1; then compounds 4 and 3 (each within the scatter of the next); then compound 2.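

In this assay, replacing hydrogen with pentyl on a saturated chain carbon bound to a carbonyl carbon gives a number 24.2 percentage points higher from compound 1 to compound 4 (beyond the scatter), a change towards a weaker effect at the concentration tested. Among these compounds, all the earlier steps changed the group on the other carbonyl carbon, so this is the first sign that the read-out also responds to the acetoxy end of the molecule, with 3-bromophenoxy kept as it is in compound 1. Nothing at hand gives a reason for this step.

Only acetyl and hexylcarbonyl are shown at this place, so it remains open how a shorter chain such as butanoyl, or a chain ending in an amine or a carboxylic acid, would read. On these data alone, it is also open whether hexylcarbonyl would have the same effect alongside (3-chlorophenyl)amino in place of 3-bromophenoxy.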